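Swapping the butyl chain for a pyridine ring

The source may report more compounds than this note shows. Statements on the series, on what has been measured and on what is new or still open speak of the compounds shown alone.

Compound 3 `CCCCCn1c(SCc2cc([N+](=O)[O-])ccc2OC)nc2cc(NC(=O)NC(C)(C)C)ccc21` gives 210 nM in an assay on isolated protein for inhibition of Gonadotropin-releasing hormone receptor (Homo sapiens); a higher number here means a weaker inhibitor, a lower number a stronger inhibitor.
Compound 2 `CCCCn1c(SCc2cc([N+](=O)[O-])ccc2OC)nc2cc(NC(=O)NC(C)(C)C)ccc21` gives 23 nM in this assay.
Compound 1 `CC(C)n1c(SCc2ccccc2Cl)nc2cc(NC(=O)C3CC3)ccc21` gives 6300 nM in this assay.

Among these three, compound 3 stands second highest in this assay: compound 2 sits below it and compound 1 above it, both gaps beyond the usual scatter. The unmeasured compound 4 `COc1ccc([N+](=O)[O-])cc1CSc1nc2cc(NC(=O)NC(C)(C)C)ccc2n1Cc1ccncc1` is reached from compound 3 by one change: pyridin-4-yl in place of butyl on a saturated chain carbon bound to an aromatic nitrogen.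

Going by the values given here, only one measured step touches the group on the aromatic nitrogen, and it is a 9.1-fold higher number from compound 2 to compound 3 (0.96 log units; beyond the scatter). That step lengthened a chain by one carbon; the new change instead replaces the whole chain end with an aromatic ring, so the measured step points only loosely at it. Compound 1 also carries a different group on the same nitrogen, but it differs from compound 3 in other places too, so its value alone cannot be read as a step. Among the compounds with values here, with the chain trimmed back from pentyl, a return toward the number of compound 2 is plausible, though the ring that enters has no counterpart among the measured compounds. The estimate for compound 4 is therefore a modest drop, a 3.5-fold lower number from compound 3 to compound 4 (0.54 log units; beyond the scatter), landing at 60 nM with a range from 10 nM to 400 nM.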

Compound 4, half-maximal inhibitory concentration: 47 nM
Beside the measured number, compound 4's estimate is 1.3-fold (0.11 log units) above it; low and high end bracket the measured number.
By their numbers in this assay, from the lowest: compound 2; then compound 4; then compound 3; then compound 1.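

In this assay, the group on the aromatic nitrogen does not have to be a plain chain: putting pyridin-4-yl in place of butyl on the saturated chain carbon gives a 4.5-fold lower number from compound 3 to compound 4 (0.65 log units; beyond the scatter) and so recovers much of what the longer chain of compound 3 had lost. The ring is bulkier by count, with six heavy atoms entering where four leave, and it brings a hydrogen-bond acceptor, yet the number still falls, so at this place the result does not simply follow the size of the group. The recovery is incomplete, however, as the comparison with the shorter chain shows a 2.0-fold higher number from compound 2 to compound 4 (0.31 log units; beyond the scatter) and leaves the chain of compound 2 with the lower number, while no measurement at hand says what lies behind either shift.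

Whether the nitrogen of the ring matters stays open, since only one ring is shown here and a plain phenyl ring, pyridin-3-yl or pyridin-2-yl on the same carbon could give quite different numbers. Also open, on these data alone, is how a shorter chain such as propyl, or a chain ending in an amine, would compare with the chain of compound 2.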